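From Fluoro to Diethylamino on Compound 2

The compounds below may be only part of what the source reports. "The series", "measured", "known", "first", "only" and "open" are said of these compounds alone.

Three related compounds have been tested so far. In a functional assay on SK-MEL-28 cells (Homo sapiens) for inhibition (a lower number here means a stronger inhibitor, a higher number a weaker inhibitor), compound 1 `Oc1ccc(/C=C/c2ccc3ccccc3c2)cc1` gives 4060 nM as a measured number. Compound 2 `COc1ccc(/C=C/c2ccc3ccccc3c2)cc1F` shows > 5000 nM and that is a limit of the assay, not a number. Compound 3 `COc1ccc(/C=C\c2ccc3ccccc3c2)cc1[N+](=O)[O-]` shows > 20000 nM and that too is a limit. Compound 2 therefore has no exact place on this scale, and only compound 1 has a firm reading.

Compound 4 `CCN(CC)c1cc(/C=C/c2ccc3ccccc3c2)ccc1OC` has not been measured yet. Compared with compound 2, it has diethylamino in place of fluoro on an aromatic carbon, ortho to a methoxy group (diethylamino in place of fluoro on an aromatic carbon). Among the compounds with values here, no measured pair shows what this kind of exchange does, so no step beyond the usual scatter is expected in this assay for now. The estimated change is a step that the limit leaves unreadable from compound 2 to compound 4 and would leave the compound in the same weak range. The estimate for compound 4 is 7000 nM (expected range 2500 nM to 20000 nM).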

Compound 4, half-maximal inhibitory concentration: > 5000 nM
Compound 4 gave a limit, no number; the forecaster's own chance of this, stated with the estimate: 55%; the middle value does not contradict the limit.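

Compound 2 and compound 4 each give only a limit of the assay, not a number, so no step can be read between them: the limit of > 5000 nM in this assay, at which 2 of the 4 values shown sit.

The compounds shown leave open how strongly either one inhibits, and whether diethylamino in place of fluoro changes that at all.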